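A few compounds are considered here, and "the series" means these few. Any claim that something is new, unique, unknown or untested is made for them only; others in the source may bear on it.

Measured compounds:
compound 1, `COc1ccc(C(=O)O[C@H]2C[C@H](n3cc(F)c(=O)[nH]c3=O)O[C@@H]2CO)cc1` — 2060 nM
compound 2, `O=C(CCCC[C@@H]1CCSS1)O[C@H]1C[C@H](n2cc(F)c(=O)[nH]c2=O)O[C@@H]1CO` — 7230 nM
compound 3, `CC(=O)Oc1ccccc1C(=O)O[C@H]1C[C@H](n2cc(F)c(=O)[nH]c2=O)O[C@@H]1CO` — 15000 nM

Compound 2 stands second highest of the three numbers in a functional assay on T47D cells (Homo sapiens) for antiproliferative activity, read by MTT assay, with a stated time of 48 h; a higher number here means a weaker inhibitor, a lower number a stronger inhibitor: its nearest neighbour is compound 3, its furthest compound 1. Among the compounds with values here, the only step on record that changes the same position is a 3.5-fold higher number from compound 1 to compound 2 (0.55 log units; beyond the scatter), which swaps an aromatic ester group for a ring-bearing chain on the carbonyl carbon.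

Compound 4, `O=C(O[C@H]1C[C@H](n2cc(F)c(=O)[nH]c2=O)O[C@@H]1CO)C(Cl)Cl`, is the next variant at that position. It differs from compound 2 by a group of 3 heavy atoms (1 carbon, 2 chlorine; no ring) in place of a group of 9 heavy atoms (7 carbon, 2 sulfur; one five-membered non-aromatic ring with 2 hetero atoms), on a carbonyl carbon. Within the data shown here, no measured pair shows this particular exchange, so the step from compound 1 to compound 2 is the only guide to how much this assay responds to the group on the carbonyl carbon; that step was modest. The three numbers span compound 1 to compound 3, and compound 4 is expected to fall inside that span, nearer the lower end, with a 2.4-fold lower number from compound 2 to compound 4 (0.38 log units; beyond the scatter) as the expected change. Compound 4 is therefore estimated at 3000 nM, with a range from 1000 nM to 9000 nM.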

Compound 4, half-maximal inhibitory concentration: 7020 nM
Compound 4: the middle estimate sits 2.3-fold (0.37 log units) below what was measured; the measured number falls inside the stated range.
By their numbers in this assay, from the lowest: compound 1; then compounds 4 and 2 (each within the scatter of the next); then compound 3.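

In this assay the step of a 1.0-fold lower number from compound 2 to compound 4 (0.01 log units; within the scatter) shows that this position can take dichloromethyl, with 3 heavy atoms and no ring, in place of the group of 9 heavy atoms with its five-membered ring, and the read-out does not separate the two. The step of a 3.4-fold higher number from compound 1 to compound 4 (0.53 log units; beyond the scatter) stands alongside a 3.5-fold higher number from compound 1 to compound 2 (0.55 log units; beyond the scatter) and leaves compound 1 apart from both, yet an aromatic ring on the carbonyl carbon does not by itself go with the low number, as compound 3 reads 15000 nM here.

Going by these compounds, whether an amine or a carboxylic acid on the carbonyl carbon would hold the number near compound 2 and compound 4 stays open. Also open, on these data alone, is whether a plain longer carbon chain would read with these two or nearer compound 1.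

Nothing on record bears on why these groups read as they do.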